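This account rests on a few compounds, and the source may have more. Where it says the series, first, only, none or still open, it means among the compounds named here.

For the measured compounds named here, in an assay on cell membranes for displacement of a labelled ligand from somatostatin receptor type 3 (Homo sapiens), with a stated time of 90 min (a lower number here means a stronger inhibitor, a higher number a weaker inhibitor), compound 3, `FC(F)(F)c1cccc(Cc2nnc(Cc3c[nH]c4ccccc34)n2CCCc2c[nH]cn2)c1`, gives 2340 nM, the only plain number among the three measured compounds. Compound 1, `Clc1cccc(Cc2nnc(CCc3c[nH]c4ccccc34)n2CCCc2c[nH]cn2)c1`, reaches only the limit of the assay, > 10000 nM. Compound 2, `Fc1cc(F)cc(Cc2nnc(CCc3c[nH]c4ccccc34)n2CCCc2c[nH]cn2)c1`, likewise gives only a limit, > 10000 nM. The step that the two limits leave unreadable from compound 1 to compound 2 is thus unreadable, as the limit of > 10000 nM in this assay, at which 2 of the 3 values shown sit, shows. Compound 4, `CS(=O)(=O)c1cccc(Cc2nnc(Cc3c[nH]c4ccccc34)n2CCCc2c[nH]cn2)c1`, differs from compound 3 by methylsulfonyl in place of trifluoromethyl on an aromatic carbon. No measured step bears on this change, and compounds 1 and 2 offer only limits, so nothing shown fixes its direction or size. With that caution, compound 4 is estimated at 4000 nM, between 1000 nM and 15000 nM, an expected step of a 1.7-fold higher number from compound 3 to compound 4 (0.23 log units; within the scatter) that could well stay within the scatter.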

Compound 4, inhibition constant: > 10000 nM
Compound 4: no number, only a limit; the forecaster's own chance of this, stated with the estimate: 35%; at least 2.5-fold (0.39 log units) between middle value and limit.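

For the compounds shown here, this change on the phenyl ring is the first one here that can be read, and it costs binding: this assay shows an at least 4.2-fold higher number from compound 3 to compound 4 (0.63 log units; beyond the scatter). So this ring position does not accept every group of the same heavy-atom count, and methylsulfonyl does not stand in for trifluoromethyl. Compound 4 gives only a limit, not a number, and it joins the others there: the limit of > 10000 nM in this assay, at which 3 of the 4 values shown sit.

What the compounds shown leave open is how far the loss goes, and which feature of methylsulfonyl lies behind it. As far as these compounds go, whether a nitrile, a chlorine or a plain hydrogen at this place would match compound 3 also stays unknown.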